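The compounds below may be only part of what the source reports. "The series", "measured", "known", "first", "only" and "open" are said of these compounds alone.

In a functional assay on HOP-62 cells (Homo sapiens) for inhibition, read by trypan blue exclusion, with a stated time of 48 h (a lower number here means a stronger inhibitor, a higher number a weaker inhibitor), compound 1 (`CCCCCCC[C@H](O)C/C=C/CCC(=O)NCC(C)C`) gives > 100000 nM, which is a limit of the assay. Compound 2 (`CCCCCCC[C@H](O)C/C=C/CCC(=O)N1CCCCC1`) gives > 100000 nM, again a limit. Among the measured compounds shown here, the only measured step, a step that the two limits leave unreadable from compound 1 to compound 2, therefore has no readable size. Compound 3 (`CCCCCCC[C@H](O)C/C=C/CCC(=O)N1CCCC1`) carries one change from compound 2, on a carbonyl carbon: pyrrolidin-1-yl in place of piperidin-1-yl on a carbonyl carbon. For the measured compounds named here, the sole guide is the limit of > 100000 nM in this assay, at which 2 of the 2 values shown sit, so no step beyond the scatter is expected, and the estimated step is a number no higher from compound 2 to compound 3 (the limit leaves the size open). Compound 3 is expected near 100000 nM, with an estimated range of 30000 nM to 200000 nM.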

Compound 3, half-maximal inhibitory concentration: > 100000 nM
Compound 3: a limit, no number (the forecaster's own chance of this, stated with the estimate: 85%); the middle value lies on the limit itself.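

In this assay, among the compounds shown here, compound 1, compound 2 and compound 3 all give only a limit, not a number, so no step among them can be read. Left open is how strong each compound truly is, and whether changing the group on the carbonyl carbon makes any difference.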